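The compounds below may be only part of what the source reports. "The series", "measured", "known", "first", "only" and "open" are said of these compounds alone.

Measured so far in an ADME assay on MRC5 cells (Homo sapiens) for cytotoxicity, read by fluorescence, with a stated time of 72 h; a higher number here means a weaker inhibitor, a lower number a stronger inhibitor:
compound 1 `O=[N+]([O-])c1cnc2n1C[C@H](COc1ccc(OC(F)(F)F)cc1)O2`: > 64000 nM
compound 2 `CC1(COc2ccc(C(F)(F)F)cn2)Cn2cc([N+](=O)[O-])nc2O1`: > 64000 nM
compound 3 `O=[N+]([O-])c1cnc2n1C[C@H](COc1ccc(-c3ccc(F)cc3)nc1)O2`: 54000 nM

Compound 2 stands only as a limit, > 64000 nM, and not as a number. Compound 1 also stands as a limit, > 64000 nM. The series is therefore dominated by the limit of > 64000 nM in this assay, at which 2 of the 3 values shown sit. Among the measured compounds shown here, compound 3 ends in a fluorinated six-membered aromatic ring and gives 54000 nM, the only actual number so far.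

Compound 4 `CC1(COc2ccc(-c3ccc(F)cn3)cn2)Cn2cc([N+](=O)[O-])nc2O1` carries 5-fluoropyridin-2-yl in place of trifluoromethyl on an aromatic carbon of compound 2: 5-fluoropyridin-2-yl in place of trifluoromethyl on an aromatic carbon. For the measured compounds named here, no measured pair isolates this change, and the limit for compound 2 leaves the size of any step open. The closest guide is compound 3 at 54000 nM, so a small move towards a lower number in this assay is expected, or none that can be resolved. The expected change is an at least 1.1-fold lower number from compound 2 to compound 4 (0.06 log units; that floor lies within the scatter). For compound 4 the estimated value is 55000 nM, with an expected range of 25000 nM to 64000 nM.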

Compound 4, half-maximal inhibitory concentration in the MRC5 assay: > 64000 nM
Compound 4: no number, only a limit; the forecaster's own chance of this, stated with the estimate: 55%; at least 1.1-fold (0.06 log units) between middle value and limit.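

In the MRC5 assay compound 4 gives only a limit (> 64000 nM). Among the compounds shown here, compound 2 also stands as a limit, so no step from compound 2 to compound 4 can be read. The compounds shown leave open whether 5-fluoropyridin-2-yl in place of trifluoromethyl changes this read-out at all. In a physicochemical assay for solubility, read by HPLC, measured as kinetic solubility, at 20 degrees C, at pH 1 (a higher number here means a more soluble compound, a lower number a less soluble compound), compound 2 gives 11 ug/mL and compound 4 gives 46 ug/mL as measured.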